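The source may hold more compounds than are shown below. What is called first, only, known or untested is meant among the compounds shown, and "the series" means these compounds.

Within the data shown here, in a functional assay on KBVIN cells (Homo sapiens) for antiproliferative activity, read by sulforhodamine B assay, with a stated time of 3 days (on this read-out higher numbers stand for an effect only at larger amounts of compound and lower numbers for an effect already at smaller amounts), three compounds on a shared core have numbers so far. Compound 1 `CCCC1=C(OC)C(CCC)(CCC)C(=O)/C(=C(O)\C=C\c2ccccc2)C1=O` gives 3.4 uM, compound 2 `CCCC1=C(OCC(C)C)C(CCC)(CCC)C(=O)/C(=C(O)\C=C\c2ccccc2)C1=O` gives 4.1 uM, and compound 3 `CCCCOC1=C(CCC)C(=O)/C(=C(O)/C=C/c2ccccc2)C(=O)C1(CCC)CCC` gives 8.9 uM, the highest of the three. Compound 4 `CCCOC1=C(CCC)C(=O)/C(=C(O)/C=C/c2ccccc2)C(=O)C1(CCC)CCC` differs from compound 3 by hydrogen in place of methyl on a saturated chain carbon, three bonds along the chain from an oxygen on an unsaturated carbon, which turns butyl into propyl. Among the measured compounds shown here, three measured steps bear on this. The step of a 2.6-fold higher number from compound 1 to compound 3 (0.42 log units; beyond the scatter) is modest and beyond the scatter, as is a 2.2-fold higher number from compound 2 to compound 3 (0.34 log units; beyond the scatter). However, the step of a 1.2-fold higher number from compound 1 to compound 2 (0.08 log units; within the scatter) stays within the scatter, so compound 2 goes against any simple link between a larger group at this oxygen and a higher number. The change to compound 4 is small, so only a slight move towards a lower number is expected, probably within the scatter. The expected change is a 1.5-fold lower number from compound 3 to compound 4 (0.17 log units; within the scatter). For compound 4 the estimated value is 6 uM, with an expected range of 3 uM to 11 uM.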

Compound 4, concentration for half-maximal effect: 2.4 uM
Estimate against measurement, compound 4: 2.5-fold (0.40 log units) above; the whole stated range lies above it.
By their numbers in this assay, from the lowest: compounds 4, 1 and 2 (each within the scatter of the next); then compound 3.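

In this assay, the change from butyl to propyl, three bonds along the chain from an oxygen on an unsaturated carbon, gives the largest step yet seen at this oxygen: a 3.7-fold lower number from compound 3 to compound 4 (0.57 log units; beyond the scatter). Both a 1.4-fold lower number from compound 1 to compound 4 (0.15 log units; within the scatter) and a 1.7-fold lower number from compound 2 to compound 4 (0.23 log units; within the scatter) stay within the scatter, so compound 4 cannot be told apart from compound 1 or compound 2. Across these four compounds, the number does not follow chain size in any steady way: compound 3 alone stands apart, and compound 2 goes against a simple link with size.

The data shown give no account of why butyl alone separates from the other groups at this oxygen. Also open, from the compounds shown here alone, is whether a longer chain such as hexyl, or a chain carrying an amine, would fall with compound 3 or with the other three.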